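The compounds below may be only part of what the source reports. "The series", "measured", "known", "first", "only" and "open" are said of these compounds alone.

Compound 1 `Cc1ccc(-c2nn(-c3ccc(S(N)(=O)=O)cc3)cc2-c2cc(-c3ccc(Cl)cc3)[nH]c2-c2ccc(F)cc2)cc1` gives 66.7% in a functional assay on the whole organism (strain Wistar albino) for inhibition, with Rattus norvegicus as the target, read by paw edema, with stated times of 1 h and 3 h, at a dose of 0.32 mmol/kg by the intraperitoneal route (a lower number here means less inhibition, a higher number more inhibition at the dose given (going by the name of the read-out)), and compound 2 `COc1ccc(-c2[nH]c(-c3ccc(Cl)cc3)cc2-c2cn(-c3ccc(S(N)(=O)=O)cc3)nc2-c2ccc(C)cc2)cc1` gives 34.2%. Among the measured compounds shown here, the single measured step, a number 32.5 percentage points lower from compound 1 to compound 2 (beyond the scatter), leaves compound 2 as the lower of the two numbers. Compound 3 `COc1ccc(-c2nn(-c3ccc(S(N)(=O)=O)cc3)cc2-c2cc(-c3ccc(Cl)cc3)[nH]c2-c2ccc(OC)cc2)cc1` differs from compound 2 by methoxy in place of methyl on an aromatic carbon. For the measured compounds named here, no measured step exchanges methyl for methoxy, so the one known step gives no direct guide to this change, and compound 3 is expected to show no step beyond the scatter, a number 0.2 percentage points lower from compound 2 to compound 3 (within the scatter). Compound 3 is therefore estimated at 34%, with a range from 20% to 50%.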

Compound 3, a percentage reported as inhibition, in the whole organism at one dose (the size of the read-out at that dose, not a potency): 28.6%
Compound 3: the middle estimate sits 5.4 percentage points above what was measured, within the range that was stated.
By their numbers in this assay, from the lowest: compounds 3 and 2 (each within the scatter of the next); then compound 1.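

In this assay, the exchange of 4-methylphenyl for 4-methoxyphenyl gives a number 5.6 percentage points lower from compound 2 to compound 3 (within the scatter), so at this position methyl and methoxy cannot be told apart. The earlier step, by contrast, concerned fluoro and methoxy on a different aromatic ring and was beyond the scatter. Nothing available explains this difference between the two positions. From the compounds shown here alone, whether an amine or a carboxylic acid at this position would shift the inhibition of paw edema remains open. So does the effect of fluoro here, on the aromatic carbon that carries methyl in compound 2.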